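A few compounds are considered here, and "the series" means these few. Any claim that something is new, unique, unknown or untested is made for them only; others in the source may bear on it.

Compound 3 `CCCc1nc(CC)c(C(=O)CCN(C(=O)c2ccncc2)c2cccnc2)n1Cc1ccc(-c2ccccc2S(=O)(=O)NC(=O)OCCC(C)C)cc1F` belongs to a small family of compounds built on one shared core and tested in an assay on isolated protein for inhibition of Type-2 angiotensin II receptor (Rattus norvegicus); a higher number here means a weaker inhibitor, a lower number a stronger inhibitor. Compound 1 `CCCc1nc(CC)c(C(=O)CCN(C(=O)c2ccccc2)c2ccccc2)n1Cc1ccc(-c2ccccc2S(=O)(=O)NC(=O)OCCC(C)C)cc1F` has repeated readings, giving 0.18 nM; 0.06 nM (2 entries), so these readings are taken together as the several entries of compound 1 in this assay, 0.18 nM; 0.06 nM (2 entries). Compound 2 `CCCc1nc(CC)c(C(=O)CCN(C(=O)c2ccncc2)c2ccccc2)n1Cc1ccc(-c2ccccc2S(=O)(=O)NC(=O)OCCC(C)C)cc1F`, which carries a pyridin-4-yl carbonyl on the amide-type nitrogen, gives 0.1 nM; its two values against those of compound 1 sit within the usual scatter, so no change can be read from them. For the measured compounds named here, compound 3 gives 1 nM, the highest number among the compounds with a single value; the one step measured so far is a 10-fold higher number from compound 2 to compound 3 (1.00 log units; beyond the scatter).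

Compound 4 `CCCc1nc(CC)c(C(=O)CCN(C(=O)CC)c2cccnc2)n1Cc1ccc(-c2ccccc2S(=O)(=O)NC(=O)OCCC(C)C)cc1F` is the next compound. Its change from compound 3 is ethyl in place of pyridin-4-yl on a carbonyl carbon, that is, the (pyridin-4-yl)carbonyl becomes a propanoyl. Going by the values given here, no measured step touches this carbonyl substituent, and the comparison of compound 1 with compound 2, the only other change at that carbonyl, stays within the scatter. Among the compounds with values here, the expectation for compound 4 in this assay is therefore a small or no step, with a lean toward a higher number, a 3.0-fold higher number from compound 3 to compound 4 (0.48 log units; beyond the scatter). Compound 4 is expected to give about 3 nM, between 0.5 nM and 15 nM.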

Compound 4, half-maximal inhibitory concentration: 0.49 nM
The estimate for compound 4 lay 6.1-fold (0.79 log units) above the measured number; the measured number lies below the stated range.
By their numbers in this assay, from the lowest: compound 2; then compound 4; then compound 3.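

At the carbonyl carbon on the amide-type nitrogen, the pyridin-4-yl ring is not needed to keep the number low in this assay: ethyl in its place gives a 2.0-fold lower number from compound 3 to compound 4 (0.31 log units; beyond the scatter), a modest step. Among the earlier compounds, this carbonyl carried only aromatic rings, phenyl in compound 1 and pyridin-4-yl in compound 2, and the readings of those two lie within the usual scatter of each other, so they could not show whether a ring was required here; compound 4 shows that a group with no ring, 2 heavy atoms in place of 6 and no hydrogen-bond acceptor, is accepted, with pyridin-3-yl on the nitrogen. Nothing given here accounts for the direction of this step.

On these data alone, it remains open whether ethyl would give a similar step with phenyl rather than pyridin-3-yl on the amide-type nitrogen. As far as these compounds go, it is also open how far the change can go at this carbonyl carbon, for example with methyl, a longer chain such as butyl, or an amine in place of ethyl.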